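The source may report more compounds than this note shows. Statements on the series, on what has been measured and on what is new or still open speak of the compounds shown alone.

Three quinazoline-based acylthiosemicarbazides were tested in a functional assay on MCF7 cells (Homo sapiens) for cytotoxicity, read by MTT assay, with a stated time of 72 h; on this read-out lower numbers stand for stronger inhibition and higher numbers for weaker inhibition. Compound 1 `COc1cc2ncnc(NNC(=S)NC(=O)c3ccc(Cl)cc3)c2cc1OC` gives 8940 nM in this assay, compound 2 `COc1cc2ncnc(NNC(=S)NC(=O)c3ccccc3OC)c2cc1OC` gives 8800 nM, and compound 3 `COc1ccccc1C(=O)NC(=S)NNc1ncnc2ccccc12` gives 8700 nM. Among the compounds with values here, only one pair differs in a single place: the step of a 1.0-fold lower number from compound 1 to compound 2 (0.01 log units; within the scatter) replaced 4-chlorophenyl with 2-methoxyphenyl on the carbonyl carbon while the shared core of compound 1 and compound 2 stayed the same, and it left the number essentially where it was. Compound 3 carries the lowest of the three numbers, but its values against compound 2 and compound 1 both lie within the scatter, so no ordering among the three can be claimed.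

Compound 4 `O=C(NC(=S)NNc1ncnc2ccccc12)c1cccc(Cl)c1` is the next compound on the core of compound 3, and the change is 3-chlorophenyl in place of 2-methoxyphenyl on a carbonyl carbon. Within the data shown here, the only measured step that bears on it is the exchange of aryl groups on the same carbonyl carbon from compound 1 to compound 2, which produced no movement beyond the scatter. A swap between 2-methoxyphenyl and a chlorophenyl at that position is therefore expected to give no step beyond the scatter in this assay, in either direction. The estimated change is a 1.0-fold higher number from compound 3 to compound 4 (0.00 log units; within the scatter). Compound 4 is thus expected to give about 8800 nM, with a range from 4400 nM to 17600 nM.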

Compound 4, half-maximal inhibitory concentration: 3540 nM
Compound 4: the middle estimate sits 2.5-fold (0.40 log units) above what was measured, and the stated range ends above it.
By their numbers in this assay, from the lowest: compound 4; then compounds 3, 2 and 1 (each within the scatter of the next).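

In this assay, the step of a 2.5-fold lower number from compound 3 to compound 4 (0.39 log units; beyond the scatter) shows that the group on the carbonyl carbon can move the number beyond the scatter, something the earlier exchange at this place (a 1.0-fold lower number from compound 1 to compound 2 (0.01 log units; within the scatter)) did not show. The two steps do not share a core, and the chlorophenyl they involve differs, being 4-chlorophenyl in compound 1 and 3-chlorophenyl in compound 4, so the flat result on the core of compound 1 cannot be taken as a rule for the core of compound 3. Nothing available explains why 3-chlorophenyl gives the lower number here.

The compounds shown leave open whether 3-chlorophenyl would give a similar step on the core of compound 1, and how 4-chlorophenyl would read on the core of compound 3. On these data alone, it also remains open how this position would respond to an amine or a carboxylic acid carried on the aromatic ring, or to a longer chain on the carbonyl carbon in place of the ring.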